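Swapping ethyl for fluoro in a non-cytotoxic series

The compounds below may be only part of what the source reports. "The series", "measured", "known", "first", "only" and "open" are said of these compounds alone.

Compound 1, `CCc1cccc(NC(=O)c2cccc(/C=C3\CC(=O)N(Cc4ccccc4)C3=O)c2)c1`, sits at the limit > 100000 nM in an ADME assay on NCM460 cells (Homo sapiens) for cytotoxicity, read by MTT assay, with a stated time of 72 h; on this read-out lower numbers stand for stronger inhibition and higher numbers for weaker inhibition.
Compound 2, `CCCCCN1C(=O)C/C(=C\c2cccc(C(=O)Nc3cccc(CC)c3)c2)C1=O`, sits at the limit > 100000 nM in this assay.
Compound 3, `CCc1cccc(NC(=O)c2cccc(/C=C3\CC(=O)N(c4ccc(C)cc4)C3=O)c2)c1`, sits at the limit > 100000 nM in this assay.

Every value shown is a limit, so compound 2 stands at that limit with the others: the limit of > 100000 nM in this assay, at which 3 of the 3 values shown sit. The measured steps a step that the two limits leave unreadable from compound 1 to compound 2, a step that the two limits leave unreadable from compound 1 to compound 3 and a step that the two limits leave unreadable from compound 2 to compound 3 all change the group on the ring nitrogen, and none of them can be read in size. Compound 4, `CCCCCN1C(=O)C/C(=C\c2cccc(C(=O)Nc3cccc(F)c3)c2)C1=O`, differs from compound 2 by fluoro in place of ethyl on an aromatic carbon, at the other end of the molecule. Among the measured compounds shown here, no measured step touches that position, and all three compounds stay at the limit, so the expected step that the limit leaves unreadable from compound 2 to compound 4 is none beyond the scatter. Compound 4 is therefore expected to give about 150000 nM, between 60000 nM and 500000 nM, most likely again reported only as a limit.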

Compound 4, half-maximal inhibitory concentration: > 100000 nM
Compound 4: only a limit was reported; the forecaster's own chance of this, stated with the estimate: 85%; the middle value does not contradict the limit.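

Compound 2 and compound 4 both stay at a limit, so no new step can be read between them: the limit of > 100000 nM in this assay, at which 4 of the 4 values shown sit.

Still open is the concentration at which any compound shown would inhibit in this assay, and whether ethyl or fluoro would make a difference there.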